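The compounds below may be only part of what the source reports. "The series", "measured", "known", "first", "only" and "open" are said of these compounds alone.

Working notes on the series.

Compound 1 `Cc1ccnc(N2C(=O)CS[C@@H]2c2cccc(C(=O)NCCCCn3cccn3)c2)c1` gives 21.9 nM in a functional assay on HOS-TE85 cells (Homo sapiens) for inhibition, read by CCK-8 assay, with a stated time of 72 h; a lower number here means a stronger inhibitor, a higher number a weaker inhibitor. Compound 3 `O=C(NCCCCn1cccn1)c1cccc(C2SCC(=O)N2c2cccc(C3CC3)c2)c1` gives 299 nM in this assay. Compound 2 `CC(C)(C)c1conc1N1C(=O)CSC1c1cccc(C(=O)NCCCCc2ccccc2)c1` returns only a limit in this assay, > 1000 nM, so no number is known for it; it sits at the limit of > 1000 nM in this assay, at which 1 of the 3 values shown sits. Within the measured set, compound 2 therefore stands at the weak end, with no value of its own to compare against compounds 1 and 3.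

Compound 4 `O=C(NCCCCc1ccccc1)c1cccc(C2SCC(=O)N2c2ccccc2F)c1` is not yet measured. It differs from compound 2 by a group of 7 heavy atoms (6 carbon, 1 fluorine; one six-membered aromatic ring of carbon only) in place of a group of 9 heavy atoms (7 carbon, 1 nitrogen, 1 oxygen; one five-membered aromatic ring with 2 hetero atoms), on an amide-type nitrogen in a ring. Compounds 1 and 3 both carry a six-membered aromatic ring on the ring nitrogen of the shared core and both give numbers inside the range of this assay, whereas compound 2, carrying the five-membered aromatic ring there, gives only a limit. On that basis a step toward stronger inhibition is expected from compound 2 to compound 4, of size an at least 2.5-fold lower number from compound 2 to compound 4 (0.39 log units; beyond the scatter), though its start is a limit and its size is uncertain. Compound 4 is therefore estimated at 400 nM, within 100 nM to 3000 nM.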

Compound 4, half-maximal inhibitory concentration: 34.1 nM
Compound 4: the middle estimate sits 12-fold (1.07 log units) above what was measured; the measured number lies below the stated range.
By their numbers in this assay, from the lowest: compounds 1 and 4 (each within the scatter of the next); then compound 3. At a limit, above all of these: compound 2.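

Putting 2-fluorophenyl in place of the five-membered aromatic ring of compound 2, on the amide-type nitrogen in a ring, gives in this assay an at least 29-fold lower number from compound 2 to compound 4 (1.46 log units; beyond the scatter). This is the only pair shown that differs in one place, so it is the first direct sign that the group at this position can by itself decide whether a number inside the range of the assay is obtained. The start of this step is a limit, not a number: the limit of > 1000 nM in this assay, at which 1 of the 4 values shown sits.

As far as these compounds go, it stays open whether plain phenyl, 2-chlorophenyl or 2-methoxyphenyl at this position would give a similar number, so the share of the fluorine cannot be separated from that of the six-membered ring. Also open, from the compounds shown here alone, is whether the same change holds with the chain that compounds 1 and 3 carry on the amide.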